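The compounds below may be only part of what the source reports. "The series", "measured", "known", "first", "only" and "open" are said of these compounds alone.

Measured compounds:
- compound 1, `Cc1nc(-c2ccccc2)c(CNCCN2CCN(C(c3ccccc3)c3ccccc3)CC2)o1`, 57.3%
- compound 2, `CCCc1nc(-c2ccccc2)c(CNCCCN2CCN(c3cccc(F)c3)CC2)o1`, 68.9%
- compound 3, `CCCc1nc(-c2ccccc2)c(CNCCN2CCN(c3ccccc3)CC2)o1`, 54.3%

In an assay on HEK293 cells for inhibition of Voltage-dependent T-type calcium channel subunit alpha-1G (Homo sapiens), read by fluorescence, tested at 10 uM (a higher number here means more inhibition at the concentration tested (going by the name of the read-out), a lower number less inhibition), compound 2 gives the highest of the three numbers. Its nearest neighbour is compound 1, which gives 57.3%, a gap beyond the scatter; the furthest is compound 3, which gives 54.3%, also beyond the scatter. Compound 2 therefore stands alone at the top of this small set.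

Compound 4, `CCCc1nc(-c2ccccc2)c(CNCCCN2CCN(c3ccccc3F)CC2)o1`, has not yet been measured in this assay. It differs from compound 2 in one place: 2-fluorophenyl in place of 3-fluorophenyl on an amine nitrogen in a ring. The two compounds share every atom and differ only in where the fluorine sits on the phenyl ring on the amine nitrogen in a ring.

Going by the values given here, no measured pair in the set shows the effect of such a change, so the size of the step cannot be read off from the data. Her account expects a step in this assay from compound 2 to compound 4 of a number 5.9 percentage points lower from compound 2 to compound 4 (within the scatter), a slight drop, within the usual scatter rather than beyond it. On that basis compound 4 is estimated at 63% in this assay, with a range from 45% to 80%.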

Compound 4, a percentage reported as inhibition, at one concentration (the size of the read-out at that concentration, not a potency): 54.4%
For compound 4 the middle estimate is 8.6 percentage points above the measured one; measured number inside the range.
By their numbers in this assay, from the lowest: compounds 3, 4 and 1 (each within the scatter of the next); then compound 2.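

In this assay the place on an amine nitrogen in a ring proves sensitive to where the fluorine sits: 2-fluorophenyl in place of 3-fluorophenyl gives a number 14.5 percentage points lower from compound 2 to compound 4 (beyond the scatter) although the two groups have the same atoms. Going by these compounds alone, the earlier compounds offered no pair differing in one place, so this is the only step in the set that can be read, and it shows that moving the fluorine alone can shift the number beyond the scatter. Nothing in the data shown explains this step.

On these data alone, what a chlorophenyl or a methoxyphenyl group would give at this place remains open. As far as these compounds go, it is also open whether moving the fluorine would give a step of similar size with a shorter chain, and each number here is a reading at one concentration rather than a potency.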